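Ethyl in Place of Benzylsulfanyl: What to Expect

This account rests on a few compounds, and the source may have more. Where it says the series, first, only, none or still open, it means among the compounds named here.

Compound 1 `Nc1ncnc2c1nc(O)n2Cc1ccc(Cl)cc1` gives 10 uM.
Compound 2 `Nc1nc(SCc2ccccc2)nc2c1nc(O)n2Cc1ccccc1` gives 0.1 uM.
Compound 3 `Nc1ncnc2c1nc(Cl)n2Cc1ccccc1` gives only a limit, > 10 uM.

These compounds were tested in a functional assay (spleen, spleen) for activation, with Mus musculus as the target; on this read-out lower numbers stand for an effect already at smaller amounts and higher numbers for an effect only at larger amounts of compound. Compound 2 has the lowest of the two numbers; compound 1 sits at a far higher number, beyond the scatter. Compound 3 sits at the limit of > 10 uM in this assay, at which 1 of the 3 values shown sits.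

Compound 4 `CCc1nc(N)c2nc(O)n(Cc3ccccc3)c2n1` has not yet been measured. It differs from compound 2 in one place: ethyl in place of benzylsulfanyl on an aromatic carbon. Without benzylsulfanyl, compound 4 is expected to move toward compound 1 and compound 3, so a step of a 30-fold higher number from compound 2 to compound 4 (1.48 log units; beyond the scatter) toward a higher number is expected. For compound 4 the estimate in this assay is 3 uM, likely between 0.5 uM and 20 uM.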

Compound 4, minimum effective concentration: 1 uM
The estimate for compound 4 lay 3.0-fold (0.48 log units) above the measured number, within the range that was stated.
By their numbers in this assay, from the lowest: compound 2; then compound 4; then compound 1.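

Among the compounds shown here, compounds 2 and 4 are the first pair here that differ in one place, so they give the first direct reading of the aromatic carbon between two ring nitrogen atoms. Ethyl in place of benzylsulfanyl gives a 10-fold higher number from compound 2 to compound 4 (1.00 log units; beyond the scatter), so this position responds to the group it carries. Even so, compound 4 with ethyl still gives an effect at 1 uM, so benzylsulfanyl is not required for activity.

Nothing shown separates the part played by the sulfur from that of the aromatic ring, or accounts for the size of this step. As far as these compounds go, how an amine or a longer carbon chain would read at this position remains open.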